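Chloro for methyl on the amine nitrogen of compound 2

The compounds below may be only part of what the source reports. "The series", "measured", "known", "first", "only" and "open" are said of these compounds alone.

The study measured two compounds in a functional assay on cells (Homo sapiens) for cytotoxicity, read by propidium iodide staining, with a stated time of 4 days; on this read-out lower numbers stand for stronger inhibition and higher numbers for weaker inhibition. Compound 1 `CNC1=CC(=O)c2c(cnc(C)c2C)C1=O` gives 19100 nM in this assay. Compound 2 `CNC1=CC(=O)c2cc(C)ncc2C1=O` gives 3040 nM, the lower of the two numbers. Within the data shown here, the single measured step, a 6.3-fold lower number from compound 1 to compound 2 (0.80 log units; beyond the scatter), concerns hydrogen in place of methyl on an aromatic carbon and lies beyond the scatter.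

Compound 3 `Cc1cc2c(cn1)C(=O)C(NCl)=CC2=O` has not yet been measured. It differs from compound 2 by chloro in place of methyl on an amine nitrogen, a change on an amine nitrogen whose other neighbour is a double-bonded ring carbon. Among the measured compounds shown here, no measured step touches this nitrogen; the only step in hand changes an aromatic carbon substituent, so it offers no direct guide to the size or direction of the present change. With nothing shown for the amine nitrogen, the expectation for compound 3 is anchored near the number for compound 2, with wide uncertainty in either direction. The expected step is a 1.6-fold higher number from compound 2 to compound 3 (0.22 log units; within the scatter). Compound 3 is therefore estimated to give 5000 nM in this assay, within a range from 1500 nM to 20000 nM.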

Compound 3, half-maximal inhibitory concentration: 5960 nM
The estimate for compound 3 lay 1.2-fold (0.08 log units) below the measured number; measured number inside the range.
By their numbers in this assay, from the lowest: compounds 2 and 3 (each within the scatter of the next); then compound 1.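

Among these compounds, compound 3 gives the first reading at the amine nitrogen: in this assay, chloro in place of methyl on this nitrogen gives a 2.0-fold higher number from compound 2 to compound 3 (0.29 log units; within the scatter), so compound 2 and compound 3 cannot be told apart on this read-out. The earlier step, a 6.3-fold lower number from compound 1 to compound 2 (0.80 log units; beyond the scatter), concerned a methyl on an aromatic carbon, and among the compounds shown it remains the only one-place change that lies beyond the scatter, while this one change on the amine nitrogen does not. Nothing measured here bears on why the exchange of methyl for chloro gives a step within the scatter.

The compounds shown leave open whether a different group on the amine nitrogen, such as a longer chain like propyl, a hydroxyl or an acetyl, would give a step beyond the scatter, as a single exchange cannot describe how this position responds in general. They also leave open whether chloro in place of methyl on this nitrogen would give a similar step on the core of compound 1, which carries the additional methyl on an aromatic carbon.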